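This account rests on a few compounds, and the source may have more. Where it says the series, first, only, none or still open, it means among the compounds named here.

In a functional assay on MCF7 cells (Homo sapiens) for antiproliferative activity, read by sulforhodamine B assay, with a stated time of 48 h (on this read-out lower numbers stand for stronger inhibition and higher numbers for weaker inhibition), compound 1 `Cc1ccc(NS(=O)(=O)c2ccc(N3CCNC3=O)cc2)cc1` gives 610 nM, compound 2 `O=C1NCCN1c1ccc(S(=O)(=O)Nc2ccc(F)cc2)cc1` gives 690 nM and compound 3 `O=C1NCCN1c1ccc(S(=O)(=O)Nc2ccc(Cl)cc2)cc1` gives 170 nM. Compound 3 thus holds the lowest number of the three. Compound 4 `O=C1NCCN1c1ccc(S(=O)(=O)Nc2ccc(OC(F)F)cc2)cc1` carries difluoromethoxy in place of chloro on an aromatic carbon, para to a large group (difluoromethoxy in place of chloro on an aromatic carbon). Among the measured compounds shown here, no measured step makes this exact change, so the evidence is indirect. Two steps end on the chloro compound: a 3.6-fold lower number from compound 1 to compound 3 (0.55 log units; beyond the scatter) and a 4.1-fold lower number from compound 2 to compound 3 (0.61 log units; beyond the scatter). Both are modest. The third, a 1.1-fold higher number from compound 1 to compound 2 (0.05 log units; within the scatter), shows no shift beyond the scatter. Among the three measured compounds, then, replacing chloro with either other group goes with a higher number, and neither compound goes against this. The same direction is expected for compound 4 in this assay, with a modest size no larger than those seen. The expected step is a 2.2-fold higher number from compound 3 to compound 4 (0.35 log units; beyond the scatter). Compound 4 is estimated at 380 nM, within an expected range of 130 nM to 1000 nM.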

Compound 4, half-maximal inhibitory concentration: 760 nM
Beside the measured number, compound 4's estimate is 2.0-fold (0.30 log units) below it; low and high end bracket the measured number.
By their numbers in this assay, from the lowest: compound 3; then compounds 1, 2 and 4 (each within the scatter of the next).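

In this assay, difluoromethoxy, which brings more heavy atoms and a hydrogen-bond acceptor, does no better than the two smaller replacements for chloro: the change gives a 4.5-fold higher number from compound 3 to compound 4 (0.65 log units; beyond the scatter) and extends the earlier finding to a third group at this position, para to a large group. The other two steps, a 1.1-fold higher number from compound 2 to compound 4 (0.04 log units; within the scatter) and a 1.2-fold higher number from compound 1 to compound 4 (0.10 log units; within the scatter), lie within the scatter, so methyl, fluoro and difluoromethoxy cannot be told apart here, and chloro alone stands apart among the four compounds. Nothing in the data shown accounts for this difference. The compounds shown leave open whether bromo, an amine or a carboxylic acid at this position would match chloro or go beyond it. They also leave open whether chloro keeps its lead on a changed core.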